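Thiazole acetic acids: pyridyl replacement at the aryl position

The source may report more compounds than this note shows. Statements on the series, on what has been measured and on what is new or still open speak of the compounds shown alone.

Measured so far:
compound 1, `O=C(O)Cc1sc(C2COc3ccccc3O2)nc1-c1ccc(Cl)cc1`: 2000 nM
compound 2, `O=C(O)Cc1sc(C(c2ccc(F)cc2)c2ccc(F)cc2)nc1-c1ccccc1`: 240 nM
compound 3, `O=C(O)Cc1sc(C(c2ccccc2)c2ccc(O)cc2)nc1-c1ccc(F)cc1`: 30 nM

In an in vitro functional assay on HEK285-7 cells for antagonist activity at prostaglandin D2 receptor 2 (Homo sapiens), read by BRET and beta-arrestin recruitment (on this read-out higher numbers stand for weaker inhibition and lower numbers for stronger inhibition), compound 2 gives 240 nM, the second highest of the three numbers; compound 3 lies beyond the scatter below it, and compound 1 beyond the scatter above it. Going by the values given here, no two measured compounds differ in a single place, so no measured step is available for the change in hand.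

Compound 4, `O=C(O)Cc1sc(C(c2ccc(F)cc2)c2ccc(F)cc2)nc1-c1ccnc(F)c1`, carries 2-fluoropyridin-4-yl in place of phenyl on an aromatic carbon. With nothing measured for this kind of change, the step of a 1.3-fold higher number from compound 2 to compound 4 (0.10 log units; within the scatter) is expected to stay within the scatter. Compound 4 is accordingly estimated at 300 nM, with a range from 80 nM to 1200 nM.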

Compound 4, half-maximal inhibitory concentration: 4.7 nM
For compound 4 the middle estimate is 64-fold (1.81 log units) above the measured one, and the stated range ends above it.
By their numbers in this assay, from the lowest: compound 4; then compound 3; then compound 2; then compound 1.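

Going by these compounds alone, the position on the aromatic carbon next to the ring nitrogen is highly sensitive to the ring it carries: in this assay, 2-fluoropyridin-4-yl in place of phenyl gives a 51-fold lower number from compound 2 to compound 4 (1.71 log units; beyond the scatter) and is the first single-place step. This change brings in the ring nitrogen and the fluorine together, so their contributions cannot be separated. No evidence bears on the cause of this step.

Open, as far as these compounds go, is whether a methoxy group or an amine in place of the fluorine preserves the gain. Also open, from the compounds shown here alone, is whether it carries over to the other groups on the shared core in compound 1 and compound 3.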